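The compounds below may be only part of what the source reports. "The series", "measured", "known", "first", "only" and "open" are said of these compounds alone.

Measured in an ADME assay on Caco-2 cells (Homo sapiens) for inhibition, read by sulforhodamine B assay, with a stated time of 72 h; on this read-out lower numbers stand for stronger inhibition and higher numbers for weaker inhibition:
- compound 1 `COc1cc(/C=C/C(=O)/C=C(/C=C/c2ccc(OC(C)=O)c(OC)c2)NC2CCCCC2)ccc1OC(C)=O` gives > 25000 nM
- compound 2 `CC(C)CNC(=C\C(=O)/C=C/c1ccc(O)cc1)/C=C/c1ccc(O)cc1` gives > 25000 nM
- compound 3 `COc1cc(/C=C/C(=O)CC(=O)/C=C/c2ccc(OC(C)=O)c(OC)c2)ccc1OC(C)=O` gives > 25000 nM

For the measured compounds named here, all three entries are limits of the assay and not numbers, so the series so far stands at the limit of > 25000 nM in this assay, at which 3 of the 3 values shown sit.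

Compound 2 gives only a limit, > 25000 nM, and has no number to set it apart from the other two compounds. Compound 4 `O=C(/C=C(/C=C/c1ccc(O)cc1)NC1CCCCC1)/C=C/c1ccc(O)cc1` differs from compound 2 by cyclohexyl in place of isobutyl on an amine nitrogen.

Going by the values given here, no step between measured compounds is available to size this change. Compound 1 also carries cyclohexylamino, and its entry is the limit > 25000 nM. On that basis, no shift beyond the scatter is expected in this assay, and compound 4 will probably also be reported as a limit. The expected change is a number no higher from compound 2 to compound 4 (the limit leaves the size open). For compound 4 the estimated value is 25000 nM, with an expected range of 10000 nM to 60000 nM.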

Compound 4, half-maximal inhibitory concentration: > 25000 nM
Compound 4: only a limit was reported; the forecaster's own chance of this, stated with the estimate: 70%; the middle value sits exactly at the limit.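

No step can be read from compound 2 to compound 4, as both entries in this assay are limits and not numbers. The compounds shown leave open how their inhibition ranks and whether cyclohexylamino and isobutylamino differ at all, with every entry at one value: the limit of > 25000 nM in this assay, at which 4 of the 4 values shown sit.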